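The compounds below may be only part of what the source reports. "The series", "measured", "known", "first", "only" and "open" are said of these compounds alone.

Measured in a functional assay on A2780 cells (Homo sapiens) for antiproliferative activity, read by MTT assay, with a stated time of 48 h; on this read-out higher numbers stand for weaker inhibition and lower numbers for stronger inhibition:
- compound 1 `COc1ccc(C(=O)c2ccc(OC)c3c2OC(C)(C)C=C3)c(NC(=O)CO)c1`: 100 nM
- compound 2 `COc1ccc(C(=O)c2ccc(OC)c3c2C=CC(C)(C)O3)c(NC(=O)CN)c1`: 890 nM
- compound 3 `COc1ccc(C(=O)c2ccc3c(c2)C=CC(C)(C)O3)c(NC(=O)CN)c1`: 590 nM

In this assay, compound 2 gives 890 nM and compound 3 gives 590 nM, two values within the scatter of each other. Compound 1 gives 100 nM, a lower number that means stronger inhibition, and its gap to compound 2 lies beyond the scatter.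

Compound 4 `COc1ccc(C(=O)c2ccc(OC)c3c2C=CC(C)(C)O3)c(NC(=O)CN(C)C)c1` departs from compound 2 in one place: dimethylamino in place of amino on a saturated chain carbon bound to a carbonyl carbon. The new group is dimethylamino in place of amino on a saturated chain carbon bound to a carbonyl carbon.

Within the data shown here, no two measured compounds differ in just one place, so the data offer no direct guide to the size of this change. The best anchor is compound 2 itself at 890 nM. The expected result is a 1.1-fold lower number from compound 2 to compound 4 (0.05 log units; within the scatter), which would be no step beyond the scatter. Compound 4 is therefore estimated at 800 nM, with an expected range of 300 nM to 2500 nM.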

Compound 4, half-maximal inhibitory concentration: 3990 nM
Compound 4: middle estimate off by 5.0-fold (0.70 log units), on the low side; measured number outside the range, above it.
By their numbers in this assay, from the lowest: compound 1; then compounds 3 and 2 (each within the scatter of the next); then compound 4.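

In this assay, dimethylamino in place of amino on a saturated chain carbon bound to a carbonyl carbon gives a 4.5-fold higher number from compound 2 to compound 4 (0.65 log units; beyond the scatter) and so weakens inhibition. Among these compounds, this is the only pair here that differs in one place, and it shows that the result is sensitive to what sits on the nitrogen at this end of the chain. The change adds carbon and also removes the hydrogen-bond donor of the amino group, but no measurement available here explains the weaker inhibition.

Methylamino at the same place would help separate the effect of adding carbon from that of losing every hydrogen on the nitrogen. Diethylamino would show whether inhibition weakens further as the groups on that nitrogen grow longer.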